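Bromo in place of chloro: from compound 2 to compound 4

The source may hold more compounds than are shown below. What is called first, only, known or untested is meant among the compounds shown, and "the series" means these compounds.

Measured in a functional assay on thoracic aorta (Rattus norvegicus, strain Wistar), with a stated time of 15 min; on this read-out higher numbers stand for an effect only at larger amounts of compound and lower numbers for an effect already at smaller amounts:
- Compound 1 `COc1ccc(Cl)cc1C(C)NC(=O)N(C)S(=O)(=O)c1ccc(Cl)cc1`: 20000 nM
- Compound 2 `COc1ccc(Cl)cc1C(C)NC(=O)NS(=O)(=O)c1ccc(Cl)cc1`: > 300000 nM
- Compound 3 `COc1ccc(OC)c(CNC(=O)N(C)S(=O)(=O)c2ccc(C)cc2)c1`: 20900 nM

In this assay compound 2 reads > 300000 nM, which is a limit of the assay and not a number.

Compound 4 `COc1ccc(Br)cc1C(C)NC(=O)NS(=O)(=O)c1ccc(Cl)cc1` keeps the amide hydrogen of compound 2 and changes one substituent. The change is bromo in place of chloro on an aromatic carbon, para to a methoxy group.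

For the measured compounds named here, only one measured step lies between compounds that differ in one place. That step is an at least 15-fold higher number from compound 1 to compound 2 (1.17 log units; beyond the scatter), a large one, with hydrogen in place of methyl on an amide-type nitrogen. Going by the values given here, it concerns a different place in the molecule, and no measured step covers the halogen exchange, so its size does not carry over.

Compound 4 is therefore expected to stay with compound 2, whose > 300000 nM is a limit. In this assay no step beyond the scatter is expected, and no direction is favoured. The estimated change is a number no higher from compound 2 to compound 4 (the limit leaves the size open).

For compound 4 the estimate is 300000 nM, with an expected range of 100000 nM to 900000 nM.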

Compound 4, half-maximal effective concentration: 80900 nM
Compound 4: middle estimate off by 3.7-fold (0.57 log units), on the high side; the whole stated range lies above it.
By their numbers in this assay, from the lowest: compounds 1 and 3 (each within the scatter of the next); then compound 4. At a limit, above all of these: compound 2.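

In this assay, the halogen on the aromatic carbon para to a methoxy group proves to matter, with an at least 3.7-fold lower number from compound 2 to compound 4 (0.56 log units; beyond the scatter) for bromo in place of chloro. The amide hydrogen alone therefore does not decide the reading, since compound 4 keeps that hydrogen and gives 80900 nM. Going by these compounds, the true size of this step stays open because compound 2 stands at a limit of the assay and not at a number: the limit of > 300000 nM in this assay, at which 1 of the 4 values shown sits.

On these data alone, it remains open whether methyl in place of the amide hydrogen would change the number as much alongside bromo as it does alongside chloro. As far as these compounds go, it is also open whether an iodo or a nitrile at this position would read closer to bromo or to chloro.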